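Swapping an Amine Tail for an Amide

The source may hold more compounds than are shown below. What is called first, only, known or untested is meant among the compounds shown, and "the series" means these compounds.

Compound 1 `COc1cc(N)c(Cl)cc1C(=O)NC1CCN(CC2CCN(CCCCN)CC2)CC1` has the lower of the two numbers recorded in an assay on striatum for inhibition of 5-hydroxytryptamine receptor 4 (Cavia porcellus), read by radioligand binding; a lower number here means a stronger inhibitor, a higher number a weaker inhibitor: compound 1 gives 6.47 nM. Compound 2 `COc1cc(N)c(Cl)cc1C(=O)NC1CCN(C(=O)C2CCN(C(=O)CCCN)CC2)CC1`, in which both linking groups are carbonyls, gives 425 nM, a weaker result lying beyond the scatter. Compound 3 `CCCC(N)C(=O)N1CCC(CN2CCC(NC(=O)c3cc(Cl)c(N)cc3OC)CC2)CC1` differs from compound 1 in one place: (1-aminobutyl)carbonyl in place of 4-aminobutyl on an amine nitrogen in a ring. Because compound 2 shows 425 nM once amide linkers replace amine linkers, a loss is expected here too, though smaller, as one amine linker is kept. The expected step is a 6.2-fold higher number from compound 1 to compound 3 (0.79 log units; beyond the scatter). Compound 3 is estimated at 40 nM, ranging from 10 nM to 200 nM.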

Compound 3, half-maximal inhibitory concentration: 2.57 nM
Compound 3: middle estimate off by 16-fold (1.19 log units), on the high side; measured number outside the range, below it.
By their numbers in this assay, from the lowest: compound 3; then compound 1; then compound 2.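

In this assay, a tail joined through a carbonyl is accepted on this amine nitrogen in a ring: (1-aminobutyl)carbonyl in place of 4-aminobutyl gives a 2.5-fold lower number from compound 1 to compound 3 (0.40 log units; beyond the scatter), a modest gain. In this pair, then, an amide at this one place does not weaken the inhibitor. Nothing measured here accounts for the step.

On these data alone, how much of the step belongs to the carbonyl alone remains open. So does whether a carboxylic acid or a longer chain would be accepted at this place.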